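This account rests on a few compounds, and the source may have more. Where it says the series, first, only, none or still open, it means among the compounds named here.

Compound 2 `O=C(CNC1CCCCC1)N1N=C(c2cc3ccccc3oc2=O)CC1c1ccccc1` gives 48500 nM in a functional assay on PC-3 cells (Homo sapiens) for cytotoxicity, read by MTT assay, with a stated time of 48 h (on this read-out higher numbers stand for weaker inhibition and lower numbers for stronger inhibition), the highest of the two numbers at hand. Compound 1 `O=C(CCl)N1N=C(c2cc3ccccc3oc2=O)CC1c1ccccc1` gives 2980 nM in this assay, and the move a 16-fold higher number from compound 1 to compound 2 (1.21 log units; beyond the scatter) was large. Compound 3 `CC1CC(C)CN(CC(=O)N2N=C(c3cc4ccccc4oc3=O)CC2c2ccccc2)C1` differs from compound 2 by 3,5-dimethylpiperidin-1-yl in place of cyclohexylamino on a saturated chain carbon bound to a carbonyl carbon. For the measured compounds named here, no measured step covers this exchange of one saturated ring amine for another, so the only known step gives no direction for it. The expected step is therefore a 1.2-fold lower number from compound 2 to compound 3 (0.08 log units; within the scatter), within the scatter. Compound 3 is estimated at 40000 nM in this assay, expected between 12000 nM and 130000 nM.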

Compound 3, half-maximal inhibitory concentration: "not active" (no number reported)
Compound 3: no number reported, so the estimate cannot be set against anything.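

For the compounds shown here, compound 3 is reported only as "not active", without a number, so no step from compound 2 to compound 3 can be read. The compounds shown leave open how far 3,5-dimethylpiperidin-1-yl in place of cyclohexylamino shifts the number. Nothing at hand bears on this result.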